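Replacing the Nitrooxyethylsulfanyl Chain with a Shorter Hydroxylated Chain

This account rests on a few compounds, and the source may have more. Where it says the series, first, only, none or still open, it means among the compounds named here.

Compound 1 `Cc1c(CCSCCO[N+](=O)[O-])cc(-c2ccc(S(C)(=O)=O)cc2)n1-c1ccccc1` was tested in an assay on J774 cells for inhibition of prostaglandin G/H synthase 1 (Mus musculus), read by immunoassay, with stated times of 15 min and 30 min; a higher number here means a weaker inhibitor, a lower number a stronger inhibitor. In this assay compound 1 gives only a limit, > 10000 nM, not a number. Compound 2 `Cc1c(CCSCCO[N+](=O)[O-])cc(-c2ccc(S(C)(=O)=O)cc2)n1-c1ccc(F)c(F)c1` carries 3,4-difluorophenyl in place of phenyl on an aromatic nitrogen; in this assay compound 2 likewise gives only a limit, > 10000 nM. Compound 3 `Cc1c(CC[S+]([O-])CCO[N+](=O)[O-])cc(-c2ccc(S(C)(=O)=O)cc2)n1-c1ccc(F)c(F)c1` is the third member of the set; in this assay compound 3 again gives only a limit, > 10000 nM. The step that the two limits leave unreadable from compound 1 to compound 2 and the step that the two limits leave unreadable from compound 2 to compound 3 stay unreadable, since all three values sit at the same limit (the limit of > 10000 nM in this assay, at which 3 of the 3 values shown sit).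

Compound 4 `Cc1c(CC[S+]([O-])CCO)cc(-c2ccc(S(C)(=O)=O)cc2)n1-c1ccccc1` differs from compound 1 in one place: a group of 5 heavy atoms (2 carbon, 2 oxygen, 1 sulfur; no ring) in place of a group of 7 heavy atoms (2 carbon, 1 nitrogen, 3 oxygen, 1 sulfur; no ring), on a saturated chain carbon, two bonds along the chain from an aromatic carbon. Among the measured compounds shown here, no measured step bears directly on this change, and the steps that are known give no readable size. The step that the limit leaves unreadable from compound 1 to compound 4 is therefore expected to show no readable change, with compound 4 remaining at the limit. For compound 4 the expected value in this assay is 20000 nM, in a range from 8000 nM to 60000 nM, most likely reported again only as a limit.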

Compound 4, half-maximal inhibitory concentration: > 10000 nM
Compound 4 gave a limit, no number (the forecaster's own chance of this, stated with the estimate: 85%); the middle value lies beyond the limit too.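

In this assay, among the compounds shown here, compound 4, like compound 1, gives only a limit and not a number, so no step between these two compounds can be read: the limit of > 10000 nM in this assay, at which 4 of the 4 values shown sit.

The compounds shown leave open how strongly any of them inhibits this enzyme, and whether changing the chain or the aromatic nitrogen substituent alters that strength.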